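The compounds below may be only part of what the source reports. "The series", "measured", "known", "first", "only" and "open" are said of these compounds alone.

Among the compounds with values here, compound 2 `O=C(Nc1cc(-c2ccccc2)nn1-c1ccccc1)c1ccccn1` stands at the top of the two numbers measured so far in an assay on isolated protein with metabotropic glutamate receptor 5 (Rattus norvegicus) as the target; on this read-out lower numbers stand for an effect already at smaller amounts and higher numbers for an effect only at larger amounts of compound: compound 2 gives 585 nM, while its nearest neighbour, compound 1 `O=C(Nc1cc(-c2ccccc2)nn1-c1ccccc1)c1ccc(F)cc1`, gives 50 nM. Within the data shown here, the one measured step, a 12-fold higher number from compound 1 to compound 2 (1.07 log units; beyond the scatter), came from a swap of the group on the carbonyl carbon. Compound 3 `O=C(Nc1cc(-c2ccccc2)nn1-c1ccccc1)c1ccccc1O` differs from compound 2 by 2-hydroxyphenyl in place of pyridin-2-yl on a carbonyl carbon, a swap at that same place bringing back a ring of carbon only, as in compound 1. A move toward lower numbers is therefore expected, estimated as a 3.9-fold lower number from compound 2 to compound 3 (0.59 log units; beyond the scatter). The estimate for compound 3 is 150 nM, within a range from 40 nM to 600 nM.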

Compound 3, half-maximal effective concentration: > 10000 nM
Compound 3: no number, only a limit (the forecaster's own chance of this, stated with the estimate: 5%); middle value at least 66-fold (1.82 log units) away from the limit.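

In this assay compound 3 gives only a limit of the assay, not a number: the limit of > 10000 nM in this assay, at which 1 of the 3 values shown sits. A ring of carbon only on the carbonyl carbon is therefore not enough for a low number: 2-hydroxyphenyl in place of pyridin-2-yl gives an at least 17-fold higher number from compound 2 to compound 3 (1.23 log units; beyond the scatter), and in place of 4-fluorophenyl it gives an at least 200-fold higher number from compound 1 to compound 3 (2.30 log units; beyond the scatter). At this place, what the ring carries matters, not only the kind of ring.

Still open, on these data alone, is whether the hydroxy group itself or its place on the ring accounts for the loss. 2-Methoxyphenyl and 4-hydroxyphenyl at the same place would help separate the two.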